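Moving the Attachment Point of an Ethylpyrazole

This account rests on a few compounds, and the source may have more. Where it says the series, first, only, none or still open, it means among the compounds named here.

Within the data shown here, in a functional assay on HCT-116 cells (Homo sapiens) for inhibition (a lower number here means a stronger inhibitor, a higher number a weaker inhibitor), compound 1 `CCCNCc1cc(-c2c(C(=O)NCC)noc2-c2cc(C(C)C)c(O)cc2O)on1` gives 117 nM, and compound 2 `CCNC(=O)c1noc(-c2cc(C(C)C)c(O)cc2O)c1-c1ccn(CC)n1` gives 25 nM, the lower of the two numbers so far. Compound 3 `CCNC(=O)c1noc(-c2cc(C(C)C)c(O)cc2O)c1-c1cnn(CC)c1` has the same atoms as compound 2, joined differently: 1-ethyl-1H-pyrazol-4-yl in place of 1-ethyl-1H-pyrazol-3-yl on an aromatic carbon. Among the measured compounds shown here, the only measured step, a 4.7-fold lower number from compound 1 to compound 2 (0.67 log units; beyond the scatter), exchanged a different pair of groups at this place, so it offers only a loose guide. For the measured compounds named here, no measurement yet isolates a shift of the pyrazole attachment point, so no clear direction can be drawn. The estimated change is small, a 1.2-fold higher number from compound 2 to compound 3 (0.08 log units; within the scatter), and is not expected to exceed the scatter. For compound 3, the expected value is 30 nM, with an estimated range of 10 nM to 90 nM.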

Compound 3, half-maximal inhibitory concentration: 26 nM
Compound 3: middle estimate off by 1.2-fold (0.06 log units), on the high side; the measured number falls inside the stated range.
By their numbers in this assay, from the lowest: compounds 2 and 3 (each within the scatter of the next); then compound 1.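

In this assay, moving the attachment point of the ethylpyrazole gives a 1.0-fold higher number from compound 2 to compound 3 (0.02 log units; within the scatter), so at this position the 1-ethyl-1H-pyrazol-3-yl and 1-ethyl-1H-pyrazol-4-yl groups cannot be told apart. The second pyrazole also improves on the group in compound 1, with a 4.5-fold lower number from compound 1 to compound 3 (0.65 log units; beyond the scatter), so that gain is not tied to one attachment point. Nothing available explains why the two attachment points read alike.

Still open, as far as these compounds go, is whether a butyl chain in place of the ethyl on the pyrazole would change the number. The same holds for a carboxylic acid on that ring.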